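A few compounds are considered here, and "the series" means these few. Any claim that something is new, unique, unknown or untested is made for them only; others in the source may bear on it.

Working notes on the sulfone series.

Compound 1 `CC1CCN(c2c(S(=O)(=O)c3ccc(Cl)c(Cl)c3)cnc3cc(F)ccc23)CC1` is the anchor. In an assay on isolated protein for displacement of a labelled ligand from metabotropic glutamate receptor 5 (Homo sapiens), with a stated time of 60 min, tested at 1 uM (on this read-out lower numbers stand for less inhibition and higher numbers for more inhibition at the one concentration tested (going by the name of the read-out)), compound 1 gives 94%. The only other measured member is compound 2 `Cc1ccc(S(=O)(=O)c2cnc3cc(Cl)ccc3c2N2CCC(C)CC2)cc1`, which in this assay gives 94%; compound 1 stands level with compound 2 at the digits shown, and the two values lie within the usual scatter of each other, so nothing separates them. Compound 2 carries a methylphenyl on the sulfonyl sulfur and a chlorine on the core, which is the only hint so far that the aryl sulfone can be varied without a change in read-out.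

The next compound, compound 3 `Cc1ccc(S(=O)(=O)c2cnc3cc(F)ccc3c2N2CCC(C)CC2)cc1F`, differs from compound 1 in one place: 3-fluoro-4-methylphenyl in place of 3,4-dichlorophenyl on a sulfonyl sulfur. Going by the values given here, no step between two measured compounds exists for this particular change, so the expectation rests on compound 1 and compound 2 being level. The step from compound 1 to compound 3 in this assay is expected to be small, a number 4 percentage points lower from compound 1 to compound 3 (within the scatter), and not clearly beyond the scatter. For compound 3 the estimate in this assay is 90%, with a range from 75% to 98%.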

Compound 3, a percentage reported as inhibition, at one concentration (the size of the read-out at that concentration, not a potency): 89%
For compound 3 the middle estimate is 1 percentage points above the measured one; low and high end bracket the measured number.
By their numbers in this assay, from the lowest: compounds 3, 1 and 2 (each within the scatter of the next).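

In this assay, going by these compounds alone, the change from 3,4-dichlorophenyl to 3-fluoro-4-methylphenyl on a sulfonyl sulfur comes to a number 5 percentage points lower from compound 1 to compound 3 (within the scatter) and gives the first comparison with only this group altered. Compound 1 and compound 2 differ in more than one place, so their level values could not be assigned to the group on the sulfonyl sulfur alone, whereas this pair holds the rest of compound 1 fixed and shows that this exchange of one substituted phenyl for another does not separate the two compounds at the single concentration tested. Nothing available bears on the reason for this result.

Every aryl group shown on the sulfonyl sulfur is a substituted phenyl carrying chlorine, methyl or fluorine, so it remains open whether the read-out holds with a carboxylic acid or an amine on that phenyl, or with a simple alkyl chain in place of the phenyl. A single-concentration percentage also leaves open whether compound 1 and compound 3 would differ in potency across a range of concentrations.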